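One Added Methyl on the Ether Chain

This account rests on a few compounds, and the source may have more. Where it says the series, first, only, none or still open, it means among the compounds named here.

In a functional assay (trachea) with Cavia porcellus as the target (on this read-out higher numbers stand for an effect only at larger amounts of compound and lower numbers for an effect already at smaller amounts), compound 1 (`C=CCCn1c(=O)c2[nH]cnc2n(CCC)c1=O`) gives 200 nM and compound 2 (`CCCn1c(=O)n(CCOC)c(=O)c2[nH]cnc21`) gives 700 nM, the higher of the two numbers. Going by the values given here, the single measured step, a 3.5-fold higher number from compound 1 to compound 2 (0.54 log units; beyond the scatter), is modest and places methoxy where vinyl stood on the saturated chain. Compound 3 (`CCCn1c(=O)n(CCOCC)c(=O)c2[nH]cnc21`) departs from compound 2 by a smaller edit: methyl in place of hydrogen on a saturated chain carbon bound to an oxygen on a saturated carbon. This puts methyl in place of hydrogen on a saturated chain carbon bound to an oxygen on a saturated carbon, turning methoxy into ethoxy. Among the compounds with values here, no measured step covers this exact change, so the step from compound 1 to compound 2 serves only as a loose guide to scale. In this assay, the expected result is a 1.3-fold lower number from compound 2 to compound 3 (0.10 log units; within the scatter), an estimated shift that stays within the scatter. Compound 3 is estimated at 550 nM, with an expected range of 220 nM to 1300 nM.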

Compound 3, half-maximal effective concentration: 70 nM
For compound 3 the middle estimate is 7.9-fold (0.90 log units) above the measured one; the whole stated range lies above it.
By their numbers in this assay, from the lowest: compound 3; then compound 1; then compound 2.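

In this assay, going by these compounds alone, the change from methoxy to ethoxy brings a 10-fold lower number from compound 2 to compound 3 (1.00 log units; beyond the scatter), so one methyl on a saturated chain carbon bound to an oxygen on a saturated carbon counts for much more at this position than the earlier compounds could show. An oxygen in the chain therefore does not by itself set the number higher: with ethoxy in place of vinyl the step is a 2.9-fold lower number from compound 1 to compound 3 (0.46 log units; beyond the scatter), the opposite direction to the step seen with methoxy. Nothing available explains why one methyl moves the number this far.

The compounds shown leave open whether the trend continues to a longer chain such as propoxy or to a branched one such as isopropoxy. They also leave open whether an amine in place of the chain oxygen would keep the low number of compound 3.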